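Adding a Hydroxy Group to Compound 1

This account rests on a few compounds, and the source may have more. Where it says the series, first, only, none or still open, it means among the compounds named here.

Compound 1 `COc1ccc(-n2cnnc2-c2cc(OC)c(OC)c(OC)c2)cc1`: 1740 nM
Compound 2 `COc1cc(-c2nncn2-c2ccc(N(C)C)cc2)cc(OC)c1OC`: 34.7 nM

In a functional assay on OVCAR-3 cells (Homo sapiens) for inhibition (on this read-out lower numbers stand for stronger inhibition of growth and higher numbers for weaker inhibition of growth), compound 1 has the higher of the two numbers, which makes it the weaker growth inhibitor of the pair. Compound 3 `COc1ccc(-n2cnnc2-c2cc(OC)c(OC)c(OC)c2)cc1O` keeps the core of compound 1 and carries hydroxy in place of hydrogen on an aromatic carbon (ortho to a methoxy group). Among the compounds with values here, the only measured step, a 50-fold lower number from compound 1 to compound 2 (1.70 log units; beyond the scatter) (dimethylamino in place of methoxy), is large but is a different change. Within the data shown here, it shows only that one swap on an aromatic carbon can move this number far. A lower number is expected, by less than that step. The expected size is a 7.0-fold lower number from compound 1 to compound 3 (0.84 log units; beyond the scatter) (an estimate). Compound 3 is estimated at 250 nM (range 40 nM to 1500 nM).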

Compound 3, concentration for 50% growth inhibition: 195 nM
For compound 3 the middle estimate is 1.3-fold (0.11 log units) above the measured one; the measured number falls inside the stated range.
By their numbers in this assay, from the lowest: compound 2; then compound 3; then compound 1.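

In this assay, placing one hydroxy group on an aromatic carbon ortho to a methoxy group gives an 8.9-fold lower number from compound 1 to compound 3 (0.95 log units; beyond the scatter). This shows that the position responds to a single added heavy atom, and that the methoxy group does not have to be replaced for the number to fall beyond the scatter. Nothing measured here explains the change.

From the compounds shown here alone, whether a fluorine atom or a carboxylic acid at this same position would lower the number as far remains open. So does whether the hydroxy group would lower the number further alongside dimethylamino.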